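Halogen swap on the anilino ring of the shared core

This account rests on a few compounds, and the source may have more. Where it says the series, first, only, none or still open, it means among the compounds named here.

Of the compounds shown here, three have numbers so far. Compound 1 `COc1ccc(-n2nnnc2Nc2ccccc2Cl)cc1` gives 246000 nM in an ADME assay on V79 cells (Cricetulus griseus) for cytotoxicity, read by MTT assay, with a stated time of 72 h; a higher number here means a weaker inhibitor, a lower number a stronger inhibitor. Compound 2 `COc1ccc(-n2nnnc2Nc2ccccc2Br)cc1` gives 239000 nM in this assay, and compound 3 `COc1ccc(-n2nnnc2Nc2cccc(F)c2)cc1` gives 248000 nM in this assay. The three numbers sit on top of one another: the change from compound 1 to compound 2 reads a 1.0-fold lower number from compound 1 to compound 2 (0.01 log units; within the scatter), from compound 1 to compound 3 a 1.0-fold higher number from compound 1 to compound 3 (0.00 log units; within the scatter), and from compound 2 to compound 3 a 1.0-fold higher number from compound 2 to compound 3 (0.02 log units; within the scatter). Compound 3 therefore cannot be set apart from either neighbour on the evidence at hand.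

Compound 4 `COc1ccc(-n2nnnc2Nc2cccc(Br)c2)cc1` differs from compound 3 in one place: bromo in place of fluoro on an aromatic carbon. Within the data shown here, the only measured step that bears on a halogen exchanged for another halogen on this ring is a 1.0-fold lower number from compound 1 to compound 2 (0.01 log units; within the scatter), which was flat, and the move of the substituent from the 2-position to the 3-position, seen in a 1.0-fold higher number from compound 1 to compound 3 (0.00 log units; within the scatter) and a 1.0-fold higher number from compound 2 to compound 3 (0.02 log units; within the scatter), was flat as well. Nothing among these steps points to a direction, so no step beyond the scatter is expected in this assay for compound 4; the step from compound 3 to compound 4 is expected to read a 1.0-fold lower number from compound 3 to compound 4 (0.01 log units; within the scatter). Compound 4 is accordingly estimated at 245000 nM, with a range from 150000 nM to 400000 nM.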

Compound 4, half-maximal inhibitory concentration: 241000 nM
Compound 4: middle estimate off by 1.0-fold (0.01 log units), on the high side; measured number inside the range.
By their numbers in this assay, from the lowest: compounds 2, 4, 1 and 3 (each within the scatter of the next).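

In this assay the change from 3-fluorophenyl to 3-bromophenyl reads a 1.0-fold lower number from compound 3 to compound 4 (0.01 log units; within the scatter) and so leaves the number flat, which extends the flat halogen exchange from the 2-substituted pair to a halogen meta to a large group. With bromo held constant, 3-bromophenyl in place of 2-bromophenyl reads a 1.0-fold higher number from compound 2 to compound 4 (0.00 log units; within the scatter) and isolates the change of place for a single halogen, while a 1.0-fold lower number from compound 1 to compound 4 (0.01 log units; within the scatter) shows that changing the halogen and its place together also gives no separation. No supporting measurement bears on these results.

On these data alone, whether a group other than a halogen on this ring, such as an amine, a carboxylic acid or a longer alkyl chain, would stay within the scatter of these four compounds remains open. Also open, as far as these compounds go, is whether replacing the methoxy group of the shared core, for example with a hydroxyl or a trifluoromethyl group, would produce a step beyond the scatter.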